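The source may report more compounds than this note shows. Statements on the series, on what has been measured and on what is new or still open speak of the compounds shown alone.

Compounds measured so far:
- compound 1, `N#Cc1ccc(CNc2nc(-c3ccccc3C(F)(F)F)nc3ccccc23)cc1`: 5700 nM
- compound 2, `FC(F)(F)c1ccccc1-c1nc(NCc2ccc(-c3ccc(Cl)c(Cl)c3)cc2)c2ccccc2n1`: 2200 nM
- compound 3, `FC(F)(F)c1cccc(-c2nc(NCc3ccc(-c4cccnc4)cc3)c3ccccc3n2)c1`: "not active" (no number reported)

In an assay on a protein complex for inhibition of ubiquitin carboxyl-terminal hydrolase 1/WD repeat-containing protein 48 (Homo sapiens), read by fluorescence (on this read-out higher numbers stand for weaker inhibition and lower numbers for stronger inhibition), compound 1 gives 5700 nM and compound 2 gives 2200 nM; the step of a 2.6-fold lower number from compound 1 to compound 2 (0.41 log units; beyond the scatter) involves 3,4-dichlorophenyl in place of cyano on an aromatic carbon. Compound 3 stands apart: in this assay compound 3 is reported as "not active" (no number reported), with no number, so it cannot be placed on the scale of the other two.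

Compound 4, `CCc1ccccc1-c1nc(NCc2ccc(-c3cccnc3)cc2)c2ccccc2n1`, differs from compound 3 by 2-ethylphenyl in place of 3-(trifluoromethyl)phenyl on an aromatic carbon. Among the compounds with values here, no measured step touches this place on the core: the one step available, from compound 1 to compound 2, alters a different position, and compounds 1 and 2 differ from compound 3 in more than one place. The expected size and direction of the step in this assay from compound 3 to compound 4 therefore rest on nothing measured, and since compound 3 carries no number, no direction can be stated at all.

Given that compound 3 gave no number, compound 4 is estimated at 12000 nM in this assay, within a range of 2500 nM to 60000 nM, with a real chance that only a limit is reported.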

Compound 4, half-maximal inhibitory concentration: 780 nM
The estimate for compound 4 lay 15-fold (1.19 log units) above the measured number; the whole stated range lies above it.
By their numbers in this assay, from the lowest: compound 4; then compound 2; then compound 1.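

In this assay compound 3 has no number and compound 4 gives 780 nM, so the step between them cannot be read. Going by these compounds, how far 2-ethylphenyl in place of 3-(trifluoromethyl)phenyl shifts the number stays open. Nothing measured here explains the result.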